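Swapping the Amide Aryl Group from Fluorine to Chlorine

The source may hold more compounds than are shown below. What is called first, only, known or untested is meant among the compounds shown, and "the series" means these compounds.

The compounds here share one core and are tested in a functional assay on ACHN cells (Homo sapiens) for cytotoxicity; a lower number here means a stronger inhibitor of growth, a higher number a weaker inhibitor of growth. Compound 1 `CCCCCCCCC(=O)N1c2ccccc2CC1C(=O)Nc1ccc(C(F)(F)F)cc1` gives 3780 nM in this assay. Compound 2 `Cc1ccc(S(=O)(=O)N2c3ccccc3CC2C(=O)Nc2ccc(C(F)(F)F)cc2)cc1` reaches only the limit of this assay, reported as > 10000 nM rather than as a number. The step of an at least 2.6-fold higher number from compound 1 to compound 2 (0.42 log units; beyond the scatter) therefore gives only a floor for how much weaker compound 2 is, since the limit of > 10000 nM in this assay, at which 1 of the 2 values shown sits, marks where its value sits. Compound 3 `Cc1ccc(S(=O)(=O)N2c3ccccc3CC2C(=O)Nc2cc(Cl)cc(Cl)c2)cc1` differs from compound 2 by 3,5-dichlorophenyl in place of 4-(trifluoromethyl)phenyl on an amide-type nitrogen. Going by the values given here, no measured step touches this part of the molecule: the one step measured, from compound 1 to compound 2, changes the group on the ring nitrogen instead. There is thus no basis for expecting a shift beyond the scatter in this assay, and compound 2 already sits at a limit. Compound 3 is estimated at 15000 nM, in a range of 5000 nM to 50000 nM, which means an expected step that the limit leaves unreadable from compound 2 to compound 3.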

Compound 3, concentration for 50% growth inhibition: > 10000 nM
Compound 3 ended at the assay's limit; the forecaster's own chance of this, stated with the estimate: 70%; the middle value is on the limit's open side.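

In this assay compound 3 gives > 10000 nM, a limit of the assay and not a number. Compound 2 stands at that same limit, so no step between compound 2 and compound 3 can be read: the limit of > 10000 nM in this assay, at which 2 of the 3 values shown sit.

From the compounds shown here alone, whether 3,5-dichlorophenyl and 4-(trifluoromethyl)phenyl on the amide-type nitrogen differ at all in this assay stays open.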